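This account rests on a few compounds, and the source may have more. Where it says the series, first, only, none or still open, it means among the compounds named here.

Among the measured compounds shown here, in a functional assay on OVCAR-3 cells (Homo sapiens) for antiproliferative activity, read by MTT assay, with a stated time of 24 h (a higher number here means a weaker inhibitor, a lower number a stronger inhibitor), compound 1 `O=C(NNc1ccccc1F)c1ccccc1NS(=O)(=O)c1cnc(O)nc1O` gives 9570 nM as the only numerical value so far. Compound 2 `O=C(NNC(=O)c1cccc(NS(=O)(=O)c2cnc(O)nc2O)c1)c1ccc(F)cc1` reads > 20000 nM and this is a limit of the assay. Compound 3 `O=C(NNC(=O)c1ccccc1NS(=O)(=O)c1cnc(O)nc1O)c1ccc(F)cc1` differs from compound 1 on an amine nitrogen whose other neighbour is an amide-type nitrogen, where (4-fluorophenyl)carbonyl stands in place of 2-fluorophenyl: (4-fluorophenyl)carbonyl in place of 2-fluorophenyl on an amine nitrogen is the whole change. No measured step sizes this change. The weaker direction is expected, on the thin ground of compound 2 at > 20000 nM as a limit. The expected move is a 1.4-fold higher number from compound 1 to compound 3 (0.13 log units; within the scatter) and it may stay within the scatter. For compound 3 the estimate is 13000 nM with an expected range of 5500 nM to 20000 nM for now.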

Compound 3, half-maximal inhibitory concentration: 15100 nM
The estimate for compound 3 lay 1.2-fold (0.07 log units) below the measured number; measured number inside the range.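

In this assay, among the compounds shown here, (4-fluorophenyl)carbonyl in place of 2-fluorophenyl on an amine nitrogen is the first change sized at this position, with a 1.6-fold higher number from compound 1 to compound 3 (0.20 log units; within the scatter). The added carbonyl is thus tolerated here without a step beyond the scatter, and the two groups cannot be ordered. Compound 2 remains a limit and not a number: the limit of > 20000 nM in this assay, at which 1 of the 3 values shown sits.

This single step cannot separate the added carbonyl from the change from 2-fluorophenyl to 4-fluorophenyl. It also leaves open how a cyclohexyl group on this nitrogen would read.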